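Toward a urea analogue in the urotensin receptor series

The source may report more compounds than this note shows. Statements on the series, on what has been measured and on what is new or still open speak of the compounds shown alone.

Three compounds share a pyrrolidine core carrying the dimethylaminopropoxy-benzyl side chain. Compound 1 `COc1ccc(C(=O)N[C@H]2CCN(Cc3ccc(OCCCN(C)C)cc3)C2)cc1OC` bears a dimethoxybenzoyl amide directly on the ring. In an assay on HEK293 cells for binding affinity to Urotensin-2 receptor (Homo sapiens), read by radioligand binding (on this read-out lower numbers stand for stronger inhibition and higher numbers for weaker inhibition), compound 1 gives only a limit, < 10000 nM, not a number. Compound 2 `CC(C)C[C@H](NC(=O)c1ccc2ccccc2n1)C(=O)N[C@H]1CCN(Cc2ccc(OCCCN(C)C)cc2)C1` inserts a leucine linker capped by a quinoline carboxamide, and in this assay compound 2 gives 631 nM. Compound 3 `CC(C)C[C@H](NC(=O)c1ccc(Br)cc1)C(=O)N[C@H]1CCN(Cc2ccc(OCCCN(C)C)cc2)C1` keeps that linker but caps it with a bromobenzoyl group, and in this assay compound 3 gives 200 nM. The single change from compound 2 to compound 3 reads as a 3.2-fold lower number from compound 2 to compound 3 (0.50 log units; beyond the scatter), so compound 3 holds the lowest of the two numbers shown, with compound 2 its nearest neighbour.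

Compound 4 `CC(C)C[C@H](NC(=O)Nc1ccccc1)C(=O)N[C@H]1CCN(Cc2ccc(OCCCN(C)C)cc2)C1` is the next variation: anilino in place of 4-bromophenyl on a carbonyl carbon. Among the compounds with values here, only one measured step exists, the cap exchange from compound 2 to compound 3, and it concerns a different pair of groups, so it does not bear directly on a change from aryl amide to aryl urea. Within the data shown here, with no step tying these two caps together, the expectation for compound 4 is a modest weakening, a step of a 2.0-fold higher number from compound 3 to compound 4 (0.30 log units; within the scatter) in this assay. Compound 4 is therefore estimated at 400 nM, within a range from 100 nM to 2000 nM.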

Compound 4, inhibition constant: 1000 nM
For compound 4 the middle estimate is 2.5-fold (0.40 log units) below the measured one; low and high end bracket the measured number.
By their numbers in this assay, from the lowest: compound 3; then compounds 2 and 4 (each within the scatter of the next).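

In this assay, within the data shown here, the exchange of 4-bromophenyl for anilino on this carbonyl carbon, which turns the aryl amide into a urea, gives a 5.0-fold higher number from compound 3 to compound 4 (0.70 log units; beyond the scatter), and it is the first measured step at this position in which one hydrogen-bond donor enters and the bromine leaves. Set against the quinoline cap, the same anilino cap gives a 1.6-fold higher number from compound 2 to compound 4 (0.20 log units; within the scatter), so these two caps cannot be ordered, and among the three caps on the leucine linker only the 4-bromophenyl of compound 3 stands apart, with a 3.2-fold lower number from compound 2 to compound 3 (0.50 log units; beyond the scatter) on its other side. Nothing at hand accounts for the size of these steps.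

The compounds shown leave open whether the weaker number of compound 4 goes with the loss of the bromine or with the entry of the urea nitrogen, since the two changes arrive together. Among these compounds, a plain benzoyl cap and a 4-bromoanilino cap would each carry only one of these changes, and either would separate them.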